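This account rests on a few compounds, and the source may have more. Where it says the series, first, only, none or still open, it means among the compounds named here.

Measured compounds in an ADME assay on Vero cells (Chlorocebus sabaeus) for cytotoxicity, read by MTT assay, tested at 25 uM; on this read-out higher numbers stand for a weaker effect at the one concentration tested and lower numbers for a stronger effect:
- compound 1, `CCOC(=O)C(C(=O)c1ccc(OC)cc1)C(NC(C)=O)c1ccc(C(C)C)cc1`: 98.8%
- compound 2, `CCOC(=O)C(C(=O)c1ccc(OC)cc1)C(NC(C)=O)c1ccc(C(C)(C)C)cc1`: 94.5%

Compound 1 and compound 2 are the only two measured points, and they sit together: a number 4.3 percentage points lower from compound 1 to compound 2 (within the scatter). So compound 1 stands at a read-out indistinguishable from compound 2, with no ordering between them.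

Compound 3, `CCOC(=O)C(C(=O)c1ccc(OC)cc1)C(NC(C)=O)c1ccc(OC)c(OC)c1`, is to be measured in this assay. It differs from compound 1 in one place: 3,4-dimethoxyphenyl in place of 4-isopropylphenyl on a saturated chain carbon bound to an amide-type nitrogen and a saturated chain carbon.

Within the data shown here, only one measured step exists, and it concerns a methyl added on the isopropyl group, not the aromatic ring that is exchanged here; it was within the scatter. Among the measured compounds shown here, no measured step touches the aryl group bound to the amide-type nitrogen carbon, so nothing on the record points to a shift in either direction. The expectation for compound 3 is therefore a read-out close to compound 1, with the step of a number 3.8 percentage points lower from compound 1 to compound 3 (within the scatter) expected to stay within the scatter. Compound 3 is estimated at 95%, between 82% and 103%.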

Compound 3, a percentage reported as activity, at one concentration (the size of the read-out at that concentration, not a potency): 99.1%
Compound 3: the middle estimate sits 4.1 percentage points below what was measured; the measured number falls inside the stated range.
By their numbers in this assay, from the lowest: compounds 2, 1 and 3 (each within the scatter of the next).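

In this assay, the aryl group on a saturated chain carbon bound to an amide-type nitrogen and a saturated chain carbon now has measured exchanges: 3,4-dimethoxyphenyl gives a number 0.3 percentage points higher from compound 1 to compound 3 (within the scatter) and a number 4.6 percentage points higher from compound 2 to compound 3 (within the scatter). This read-out therefore does not tell the oxygen-bearing 3,4-dimethoxyphenyl from the all-carbon 4-isopropylphenyl or 4-(tert-butyl)phenyl, which the earlier step on the isopropyl group alone could not show. Nothing available explains this flat result.

On these data alone, whether an aryl group carrying an amine or a carboxylic acid at this place would also stay level with these three compounds remains open. As far as these compounds go, the effect of changes elsewhere on the shared core, such as a longer chain in place of the ethyl ester, also remains open.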